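From Compound 3 to a Methoxy Counterpart

The source may hold more compounds than are shown below. What is called first, only, known or untested is meant among the compounds shown, and "the series" means these compounds.

Of the compounds shown here, three sharing one core have been measured in an ADME assay on HUVEC cells (Homo sapiens) for cytotoxicity, read by MTT assay, with a stated time of 24 h; a higher number here means that more compound is tolerated, a lower number that less compound is tolerated. Compound 1 `Cc1ccccc1/C=C/c1nnc(-c2ccc3c(c2)OCCO3)o1` gives 356000 nM, compound 2 `Cc1cccc(/C=C/c2nnc(-c3ccc4c(c3)OCCO4)o2)c1` gives 201000 nM, and compound 3 `C(=C/c1nnc(-c2ccc3c(c2)OCCO3)o1)\c1ccccc1` gives 209000 nM. Compound 3 therefore stands with the other two, and all three numbers lie within the scatter of one another.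

Compound 4 `COc1cccc(/C=C/c2nnc(-c3ccc4c(c3)OCCO4)o2)c1` carries methoxy in place of hydrogen on an aromatic carbon, meta to a large group (methoxy in place of hydrogen on an aromatic carbon). Among the compounds with values here, no measured compound carries methoxy, so the nearest evidence comes from exchanges of methyl and hydrogen on an aromatic carbon. These are a 1.7-fold lower number from compound 1 to compound 3 (0.23 log units; within the scatter) and a 1.0-fold higher number from compound 2 to compound 3 (0.02 log units; within the scatter). Moving the methyl gives a 1.8-fold lower number from compound 1 to compound 2 (0.25 log units; within the scatter). Going by these compounds, all of these steps stay within the scatter, so no step beyond the scatter is expected in this assay, although the methoxy exchange itself is untested. The expected change is a 1.0-fold higher number from compound 3 to compound 4 (0.00 log units; within the scatter). For compound 4 the estimated value is 210000 nM, with an expected range from 110000 nM to 400000 nM.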

Compound 4, half-maximal cytotoxic concentration: 332000 nM
Compound 4: middle estimate off by 1.6-fold (0.20 log units), on the low side; low and high end bracket the measured number.
By their numbers in this assay, from the lowest: compounds 2, 3, 4 and 1 (each within the scatter of the next).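

Methoxy is the first group other than methyl to be seen on this aromatic carbon, and in this assay its exchange for hydrogen gives a 1.6-fold higher number from compound 3 to compound 4 (0.20 log units; within the scatter) and so stays within the scatter. The exchange for methyl gives a 1.7-fold higher number from compound 2 to compound 4 (0.22 log units; within the scatter) and the change from the 2-methylphenyl group to 3-methoxyphenyl gives a 1.1-fold lower number from compound 1 to compound 4 (0.03 log units; within the scatter) so that a group with an oxygen, meta to a large group, also leaves the number within the scatter of all three earlier compounds. No measurement shown here explains these steps.

Going by these compounds, whether an amine, a carboxylic acid or a longer chain such as butoxy at this place would give a step beyond the scatter remains open. On these data alone, it also remains open how methoxy would read on the other aromatic carbons of this ring.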